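This account rests on a few compounds, and the source may have more. Where it says the series, first, only, none or still open, it means among the compounds named here.

In an ADME assay on MT4 cells (Homo sapiens) for cytotoxicity, read by MTT assay, with a stated time of 5 days (a lower number here means that less compound is tolerated, a higher number that more compound is tolerated), compound 2 `Cc1cc(C#N)cc(C)c1Oc1nc(Nc2ccc(C#N)cc2)ncc1-c1ccoc1`, which carries furan-3-yl, gives 4980 nM. Within the data shown here, its only neighbour with a true number is compound 3 `Cc1cc(C#N)cc(C)c1Oc1nc(Nc2ccc(C#N)cc2)ncc1-c1ccsc1` at 3920 nM, and the two stand level, with a 1.3-fold lower number from compound 2 to compound 3 (0.10 log units; within the scatter). Compound 1 `COc1ccc(-c2cnc(Nc3ccc(C#N)cc3)nc2Oc2c(C)cc(C#N)cc2C)cc1`, which carries 4-methoxyphenyl at the same place, reports only a limit of > 279000 nM. The large steps away from that group are an at least 56-fold lower number from compound 1 to compound 2 (1.74 log units; beyond the scatter) and an at least 71-fold lower number from compound 1 to compound 3 (1.85 log units; beyond the scatter).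

Compound 4 `Cc1cc(C#N)cc(C)c1Oc1nc(Nc2ccc(C#N)cc2)ncc1-c1cccnc1` has pyridin-3-yl in place of furan-3-yl on an aromatic carbon. Like 4-methoxyphenyl, the entering group is a six-membered aromatic ring, so compound 4 is expected to move part of the way back towards compound 1, given an at least 56-fold lower number from compound 1 to compound 2 (1.74 log units; beyond the scatter). Against a full return stands a 1.3-fold lower number from compound 2 to compound 3 (0.10 log units; within the scatter), which shows that one swap of a ring with a single hetero atom can leave the number unmoved. The expected change is a moderate rise, estimated as a 3.0-fold higher number from compound 2 to compound 4 (0.48 log units; beyond the scatter). Compound 4 is estimated at 15000 nM, with the measurement expected between 3500 nM and 80000 nM.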

Compound 4, half-maximal cytotoxic concentration: 13500 nM
Beside the measured number, compound 4's estimate is 1.1-fold (0.05 log units) above it; low and high end bracket the measured number.
By their numbers in this assay, from the lowest: compounds 3 and 2 (each within the scatter of the next); then compound 4. At a limit, above all of these: compound 1.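

In this assay, pyridin-3-yl stands apart from both five-membered rings, with a 2.7-fold higher number from compound 2 to compound 4 (0.43 log units; beyond the scatter) and a 3.4-fold higher number from compound 3 to compound 4 (0.54 log units; beyond the scatter). A swap of one ring with a single hetero atom for another at this position can therefore move the number beyond the scatter, which the two five-membered rings alone did not show. A six-membered aromatic ring alone does not restore the tolerance seen with 4-methoxyphenyl, with an at least 20-fold lower number from compound 1 to compound 4 (1.31 log units; beyond the scatter), and the true size of that step stays unknown because compound 1 is reported only as a limit: the limit of > 279000 nM in this assay, at which 1 of the 4 values shown sits.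

The compounds shown leave open whether the six-membered ring, its nitrogen or the methoxy group accounts for these gaps, a question that a plain phenyl ring at this place would address. Going by these compounds, how a non-aromatic group such as an amine or a short alkyl chain would fare here also remains open.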